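Taking the methoxy group off compound 3

The source may report more compounds than this note shows. Statements on the series, on what has been measured and on what is new or still open speak of the compounds shown alone.

In a functional assay on HepG2 cells (Homo sapiens) for inhibition, read by MTT assay, with a stated time of 48 h (a higher number here means a weaker inhibitor, a lower number a stronger inhibitor), compound 3 `COc1ccc(-c2nc3c(c(-c4ccccc4)nn3-c3ccccc3)c(-c3ccc(N4CCN(C)CC4)cc3)c2C#N)cc1` gives 1330 nM, the lowest of three numbers, while compound 2 `CN1CCN(c2ccc(-c3c(C#N)c(-c4ccc(Cl)cc4)nc4c3c(-c3ccccc3)nn4-c3ccccc3)cc2)CC1` gives 14600 nM and compound 1 `N#Cc1c(-c2ccccc2)nc2c(c(-c3ccccc3)nn2-c2ccccc2)c1-c1ccc(N2CCCCC2)cc1` gives 30900 nM. Compound 4 `CN1CCN(c2ccc(-c3c(C#N)c(-c4ccccc4)nc4c3c(-c3ccccc3)nn4-c3ccccc3)cc2)CC1` is compound 3 with hydrogen in place of methoxy on an aromatic carbon, turning 4-methoxyphenyl into phenyl (hydrogen in place of methoxy on an aromatic carbon). For the measured compounds named here, one measured step bears on this change: an 11-fold lower number from compound 2 to compound 3 (1.04 log units; beyond the scatter), a large step beyond the scatter, with methoxy in place of chloro on an aromatic carbon. Going by the values given here, no measurement yet compares hydrogen with either group, so only a rough guess is possible. Losing the methoxy is expected to raise the number, by a somewhat smaller amount, an estimated 4.1-fold higher number from compound 3 to compound 4 (0.62 log units; beyond the scatter). For compound 4 the expected value is 5500 nM, within an estimated range of 1500 nM to 20000 nM.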

Compound 4, half-maximal inhibitory concentration: 3140 nM
For compound 4 the middle estimate is 1.8-fold (0.24 log units) above the measured one; measured number inside the range.
By their numbers in this assay, from the lowest: compound 3; then compound 4; then compound 2; then compound 1.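

Within this assay, hydrogen gives this position a reference point, and the plain phenyl of compound 4 falls between the two substituted rings: losing methoxy raises the number (a 2.4-fold higher number from compound 3 to compound 4 (0.37 log units; beyond the scatter)), while losing chloro lowers it (a 4.6-fold lower number from compound 2 to compound 4 (0.67 log units; beyond the scatter)). Compound 4 also allows a one-place comparison of the two amine rings, with 4-methylpiperazin-1-yl in place of piperidin-1-yl (a 9.8-fold lower number from compound 1 to compound 4 (0.99 log units; beyond the scatter)). No measurement here explains these steps.

As far as these compounds go, whether other groups at this position, such as fluoro, hydroxy or dimethylamino, would follow the same order remains open.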